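Swapping a nitro-bearing ring for a nitrile-bearing one

The source may hold more compounds than are shown below. What is called first, only, known or untested is meant among the compounds shown, and "the series" means these compounds.

Of the compounds shown here, three of one family have been measured so far in a functional assay on THP-1 cells (Homo sapiens) for cytotoxicity, read by MTT assay, with a stated time of 24 h; a lower number here means a stronger inhibitor, a higher number a weaker inhibitor. Compound 1 `COc1cc(/C=C2\CN(C)C/C(=C\c3cccc([N+](=O)[O-])c3)C2=O)cc(OC)c1` gives 1770 nM in this assay. Compound 2 `COc1cc(/C=C2\CN(C)C/C(=C\c3ccc(C#N)cc3)C2=O)cc(OC)c1` gives 940 nM in this assay. Compound 3 `COc1cc(/C=C2\CN(C)C/C(=C\c3cccc([N+](=O)[O-])c3)C2=O)cc(OC)c1OC` gives 890 nM in this assay.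

Compound 2 arises from compound 1 by a single change, (4-cyanophenyl in place of 3-nitrophenyl on a double-bonded chain carbon bound to a double-bonded ring carbon), and this change gave a 1.9-fold lower number from compound 1 to compound 2 (0.27 log units; within the scatter). Compound 3 arises from compound 1 by a different change, (methoxy in place of hydrogen on an aromatic carbon), which gave a 2.0-fold lower number from compound 1 to compound 3 (0.30 log units; within the scatter). The difference between compound 3 and compound 2 is not broken down here; their two values lie close to each other.

Compound 4 `COc1cc(/C=C2\CN(C)C/C(=C\c3ccc(C#N)cc3)C2=O)cc(OC)c1OC` has not yet been measured. It differs from compound 3 in one place, (4-cyanophenyl in place of 3-nitrophenyl on a double-bonded chain carbon bound to a double-bonded ring carbon). This is the same change that turns compound 1 into compound 2, made on the core of compound 3 instead of the core of compound 1; the two cores differ by methoxy in place of hydrogen on an aromatic carbon. Among the compounds shown, the change occurs in two pairs in all.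

Within the data shown here, with only one earlier instance to go by, the expectation for compound 4 is a step of about the same size and direction, a 1.6-fold lower number from compound 3 to compound 4 (0.21 log units; within the scatter), resting on the earlier step of a 1.9-fold lower number from compound 1 to compound 2 (0.27 log units; within the scatter). Compound 4 is therefore estimated at 550 nM in this assay, with a range from 250 nM to 1300 nM.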

Compound 4, half-maximal inhibitory concentration: 820 nM
Beside the measured number, compound 4's estimate is 1.5-fold (0.17 log units) below it, within the range that was stated.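

Putting 4-cyanophenyl in place of 3-nitrophenyl a second time gives a 1.1-fold lower number from compound 3 to compound 4 (0.04 log units; within the scatter) in this assay, and this step cannot be told apart from its earlier instance on the other core: the same change on two cores in this assay, a 1.9-fold lower number (0.27 log units; within the scatter) from compound 1 to compound 2 and a 1.1-fold lower number (0.04 log units; within the scatter) from compound 3 to compound 4, 1.7-fold (0.24 log units) apart, within the scatter of two such steps. The methoxy change reads the same way, giving a 1.1-fold lower number from compound 2 to compound 4 (0.06 log units; within the scatter), and it also agrees with its earlier instance: the same change on two cores in this assay, a 2.0-fold lower number (0.30 log units; within the scatter) from compound 1 to compound 3 and a 1.1-fold lower number (0.06 log units; within the scatter) from compound 2 to compound 4, 1.7-fold (0.24 log units) apart, within the scatter of two such steps. The four compounds therefore show no detectable difference in how either change behaves on the two cores, but each of the four steps lies within the scatter, which means they do not establish that either change has a real effect here or that such an effect would carry from one core to the other.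

A step beyond the scatter would test that carrying-over far better, and whether an amine or a carboxylic acid in place of the nitrile would give such a step stays open, as neither group is among the compounds shown. From the compounds shown here alone, it also stays open whether a longer chain in place of the methoxy group would behave alike on both cores.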